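Working notes: trifluoromethyl for hydroxymethyl, cytotoxicity on MT2 cells

The source may hold more compounds than are shown below. What is called first, only, known or untested is meant among the compounds shown, and "the series" means these compounds.

Measured compounds:
compound 1 `N#CSCc1nc(-c2ccc(C(=O)O)cc2)no1`: 383000 nM in an ADME assay on MT2 cells (Homo sapiens) for cytotoxicity, read by XTT assay, with a stated time of 4 days; a higher number here means that more compound is tolerated, a lower number that less compound is tolerated
compound 2 `O=C(O)c1ccc(-c2noc(CO)n2)cc1`: 455000 nM in this assay

Going by the values given here, compound 2 holds the highest of the two numbers in this assay; its only neighbour is compound 1, and the step of a 1.2-fold higher number from compound 1 to compound 2 (0.07 log units; within the scatter) lies within the scatter, so the two compounds cannot be ordered on these data.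

Compound 3 `O=C(O)c1ccc(-c2noc(C(F)(F)F)n2)cc1` differs from compound 2 by trifluoromethyl in place of hydroxymethyl on an aromatic carbon. Among the compounds with values here, the single measured step, a 1.2-fold higher number from compound 1 to compound 2 (0.07 log units; within the scatter), concerns a different group at a different place and did not move the number beyond the scatter. Within the data shown here, no measured step bears on a trifluoromethyl or on the aromatic carbon of the five-membered aromatic ring with 2 nitrogen and 1 oxygen. The expectation is therefore a step of a 1.1-fold lower number from compound 2 to compound 3 (0.06 log units; within the scatter) in this assay, none beyond the scatter. Compound 3 is estimated to give 400000 nM, with a range of 200000 nM to 800000 nM.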

Compound 3, half-maximal cytotoxic concentration: 82300 nM
Estimate against measurement, compound 3: 4.9-fold (0.69 log units) above; the measured number lies below the stated range.
By their numbers in this assay, from the lowest: compound 3; then compounds 1 and 2 (each within the scatter of the next).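

At this aromatic carbon of the core, this assay does respond to the group: trifluoromethyl in place of hydroxymethyl gives a 5.5-fold lower number from compound 2 to compound 3 (0.74 log units; beyond the scatter), a step beyond the scatter that the earlier pair did not show. Trifluoromethyl in place of (cyanosulfanyl)methyl gives a 4.7-fold lower number from compound 1 to compound 3 (0.67 log units; beyond the scatter), so the change reads the same from either chain, and those two chains themselves cannot be ordered. No measurement at hand accounts for the lower number with trifluoromethyl.

The compounds shown leave open whether the lower number belongs to trifluoromethyl alone or extends to other groups at this place; a methyl, a difluoromethyl or an aminomethyl would speak to that. Also open, from the compounds shown here alone, is whether the step holds when an ester or an amide replaces the carboxylic acid of the core.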